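Cytotoxicity of a deoxyuridine analogue after a side-chain swap

The source may report more compounds than this note shows. Statements on the series, on what has been measured and on what is new or still open speak of the compounds shown alone.

Of the compounds shown here, three have been measured in an ADME assay on L1210/0 cells (Mus musculus) for cytotoxicity, with a stated time of 48 h; on this read-out lower numbers stand for stronger inhibition and higher numbers for weaker inhibition. Compound 1 `COc1ccc(C(=O)/C=C/c2cc(=O)[nH]c(=O)n2COCCO)cc1` gives 33500 nM. Compound 2 `C=C(Cl)c1cn([C@H]2C[C@H](O)[C@@H](CO)O2)c(=O)[nH]c1=O` gives 1660 nM, the lowest of the two numbers shown, and the gap up to compound 1 lies beyond the usual scatter. For compound 3 `O=C1O/C(=C\Cn2ccc(=O)[nH]c2=O)C(Cc2ccccc2)=C1O` only a limit is reported, > 200000 nM; this limit is the point at which (the limit of > 200000 nM in this assay, at which 1 of the 3 values shown sits).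

Compound 4 `CS(=O)(=O)Cc1cn([C@H]2C[C@H](O)[C@@H](CO)O2)c(=O)[nH]c1=O` has not yet been measured in this assay. It differs from compound 2 in a single place: (methylsulfonyl)methyl in place of 1-chloroethenyl on an aromatic carbon. For the measured compounds named here, no measured pair shows the effect of such a change, so the step from compound 2 to compound 4 in this assay cannot be read from the data. Given that compound 2 gives 1660 nM while the compounds bearing other side chains on their cores sit higher, a loss of potency beyond the scatter is expected, meaning a step of an 18-fold higher number from compound 2 to compound 4 (1.26 log units; beyond the scatter). Compound 4 is therefore estimated to give 30000 nM, with a range from 5000 nM to 200000 nM.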

Compound 4, half-maximal inhibitory concentration: > 200000 nM
Compound 4 gave a limit, no number (the forecaster's own chance of this, stated with the estimate: 30%); at least 6.6-fold (0.82 log units) between middle value and limit.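

In this assay, for the compounds shown here, the replacement of 1-chloroethenyl by (methylsulfonyl)methyl on an aromatic carbon is the first single-place change available, and it gives an at least 120-fold higher number from compound 2 to compound 4 (2.08 log units; beyond the scatter). This shows that the group at this position alone can take the shared core from a measured number to a limit, and that the change is not tolerated here. The result for compound 4 is a limit and not a number, so the step gives only the smallest possible size of the change, and such a limit occurs more than once: the limit of > 200000 nM in this assay, at which 2 of the 4 values shown sit.

The compounds shown leave open whether the loss of 1-chloroethenyl or the arrival of (methylsulfonyl)methyl matters more. An ethyl group, a bromine atom or an aminomethyl group at this position could begin to separate the two.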